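A Carboxyethyl Amide Tested for Antiproliferative Potency

This account rests on a few compounds, and the source may have more. Where it says the series, first, only, none or still open, it means among the compounds named here.

Three compounds have been measured in a functional assay on PC-3 cells (Homo sapiens) for antiproliferative activity, read by MTT assay, with a stated time of 24 h; on this read-out higher numbers stand for weaker inhibition and lower numbers for stronger inhibition:

compound 1 `CCn1c(C(=O)N[C@@H](CC(=O)OC)C(=O)OC)ccc1C(CC)(CC)c1ccc(OCS(=O)(=O)c2ccccc2)c(C)c1` gives 6490 nM
compound 2 `CCn1c(C(=O)N[C@H](CO)CCO)ccc1C(CC)(CC)c1ccc(OCS(=O)(=O)c2ccccc2)c(C)c1` gives 12100 nM
compound 3 `CCn1c(C(=O)N[C@H](C(=O)O)C(C)C)ccc1C(CC)(CC)c1ccc(OCS(=O)(=O)c2ccccc2)c(C)c1` gives 3650 nM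

Among these three numbers compound 1 stands second highest. Its nearest neighbour is compound 3, reached by a 1.8-fold lower number from compound 1 to compound 3 (0.25 log units; within the scatter), and its furthest is compound 2, reached by a 1.9-fold higher number from compound 1 to compound 2 (0.27 log units; within the scatter). Compound 2 and compound 3 are separated by a 3.3-fold lower number from compound 2 to compound 3 (0.52 log units; beyond the scatter).

Compound 4 `CCn1c(C(=O)NCCC(=O)O)ccc1C(CC)(CC)c1ccc(OCS(=O)(=O)c2ccccc2)c(C)c1` has not yet been measured. It differs from compound 1 in one place: 2-carboxyethyl in place of 1,2-bis(methoxycarbonyl)ethyl on an amide-type nitrogen. Like compound 3, compound 4 carries a carboxy group on the chain attached to the amide-type nitrogen, whereas compound 1 carries the 1,2-bis(methoxycarbonyl)ethyl group there. Going by the values given here, the step that bears most directly on this is the one from compound 1 to compound 3, which stayed within the scatter; the step from compound 2 to compound 3 was modest and beyond the scatter, and points the same way. A step of a 1.3-fold lower number from compound 1 to compound 4 (0.11 log units; within the scatter) is therefore expected in this assay. The estimate for compound 4 in this assay is 5000 nM, within a range from 2000 nM to 12500 nM.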

Compound 4, half-maximal inhibitory concentration: 14400 nM
The estimate for compound 4 lay 2.9-fold (0.46 log units) below the measured number; measured number outside the range, above it.
By their numbers in this assay, from the lowest: compounds 3, 1, 2 and 4 (each within the scatter of the next, the first and the last beyond it).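

In this assay, a carboxy group on the chain at the amide-type nitrogen does not settle the number on its own: 2-carboxyethyl in place of 1-carboxy-2-methylpropyl gives a 3.9-fold higher number from compound 3 to compound 4 (0.60 log units; beyond the scatter), so two carboxy-bearing chains can read differently. The change from the ester-bearing group also has a measurable size, with 2-carboxyethyl in place of 1,2-bis(methoxycarbonyl)ethyl giving a 2.2-fold higher number from compound 1 to compound 4 (0.35 log units; beyond the scatter); the step from the earlier hydroxy-bearing chain, 3-hydroxy-1-(hydroxymethyl)propyl, is a 1.2-fold higher number from compound 2 to compound 4 (0.08 log units; within the scatter), which stays within the scatter, so this assay does not separate those two chains. No measurement is available to explain any of these differences.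

The step from 1-carboxy-2-methylpropyl to 2-carboxyethyl changes the chain's branching, its defined stereocentre and the placing of the carboxy group all at once, and the compounds shown cannot separate these changes. A 1-carboxyethyl or 3-carboxypropyl group, or an amine in place of the carboxy group on the 2-carboxyethyl chain, would test which of these features tracks with the number at this nitrogen.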